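Amide variation on the aryloxy side chain

The source may report more compounds than this note shows. Statements on the series, on what has been measured and on what is new or still open speak of the compounds shown alone.

Going by the values given here, compound 2 `CCCCc1oc2ccccc2c1C(=O)c1ccc(OCCCC(=O)N2CCCC2)cc1` carries the shared core with a 2-((pyrrolidin-1-yl)carbonyl)ethyl group on a saturated chain carbon bound to an oxygen on an aromatic ring; in a functional assay on HL-60 cells (Homo sapiens) for antiproliferative activity, read by MTT assay, with a stated time of 24 h (on this read-out lower numbers stand for stronger inhibition and higher numbers for weaker inhibition), compound 2 gives 29900 nM, the only number in the set. Compound 1 `CCCCc1oc2ccccc2c1C(=O)c1ccc(OCC(=O)Nc2cccc(OC)c2)cc1`, with (3-methoxyphenyl)carbamoyl in that place, gives in this assay only a limit of the assay, > 50000 nM. Among the compounds with values here, the single measured step, an at least 1.6-fold lower number from compound 1 to compound 2 (0.22 log units; that floor lies within the scatter), rests on the limit of > 50000 nM in this assay, at which 1 of the 2 values shown sits, and its floor lies within the scatter. Compound 3 `CCCCc1oc2ccccc2c1C(=O)c1ccc(OCCCC(=O)N[C@@H](C)c2ccccc2)cc1` differs from compound 2 by (1-phenylethyl)amino in place of pyrrolidin-1-yl on a carbonyl carbon. Within the data shown here, no measured step changes the amide substituent alone, and the step from compound 1 to compound 2 also moves the linker, so it gives no direction for this change. A step within the scatter is expected, a 1.2-fold lower number from compound 2 to compound 3 (0.08 log units; within the scatter). Compound 3 is therefore estimated at 25000 nM, between 9000 nM and 60000 nM.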

Compound 3, half-maximal inhibitory concentration: > 50000 nM
Compound 3 ended at the assay's limit; the forecaster's own chance of this, stated with the estimate: 35%; at least 2.0-fold (0.30 log units) between middle value and limit.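

Going by these compounds alone, with the chain on the aryloxy oxygen held constant, this is the first step that changes the amide substituent alone: an at least 1.6-fold higher number from compound 2 to compound 3 (0.22 log units; that floor lies within the scatter). In this assay, on these data alone, compound 3 gives > 50000 nM, which is a limit of the assay and not a number, so the size of the step stays unknown and only its floor is fixed. Replacing pyrrolidin-1-yl with (1-phenylethyl)amino on a carbonyl carbon therefore gives no measurable gain in this series, and the reading is bounded by a limit: the limit of > 50000 nM in this assay, at which 2 of the 3 values shown sit.

As far as these compounds go, whether dimethylamino, piperidin-1-yl or benzylamino on that carbonyl carbon would give a number under the limit remains open. The effect of chain length alone also remains open, as no pair shown changes only the chain.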